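Turning one stereocentre: from compound 2 to compound 3

The source may hold more compounds than are shown below. What is called first, only, known or untested is meant among the compounds shown, and "the series" means these compounds.

Of the compounds shown here, two have numbers so far. Compound 1 `CCN(CC)c1nc(Cl)nc(NC(C)c2ccccc2)n1` gives 1510 nM in an ADME assay on the whole organism for inhibition, with Echinochloa crus-galli var. formosensis as the target, with a stated time of 4 days; a lower number here means a stronger inhibitor, a higher number a weaker inhibitor. Compound 2 `CC[C@@H](C)Nc1nc(Cl)nc(N[C@@H](C)c2ccccc2)n1` gives 7410 nM in this assay, the higher of the two numbers, and its gap to compound 1 lies beyond the usual scatter of repeated measurements, so compound 2 is the weaker inhibitor of the pair.

Compound 3 `CC[C@@H](C)Nc1nc(Cl)nc(N[C@H](C)c2ccccc2)n1` has not yet been measured. It differs from compound 2 in a single way: the two compounds have the same atoms and bonds and differ only in configuration as drawn: 1 of 2 stereo elements differ; a stereocentre at a saturated chain carbon is drawn S in compound 2 and R in compound 3. Nothing leaves and nothing enters; only the drawn configuration at one chain carbon is turned around.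

Within the data shown here, no pair of measured compounds differing in one place has been recorded, so there is no step to lean on. Mirror-image centres can give numbers that are close or far apart, and in either direction, and nothing among compound 1 and compound 2 settles which way this one will go. The change from compound 2 to compound 3 is therefore expected to be about a 1.9-fold lower number from compound 2 to compound 3 (0.27 log units; within the scatter), with wide uncertainty. Compound 3 is estimated to give 4000 nM in this assay, likely between 800 nM and 20000 nM.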

Compound 3, half-maximal inhibitory concentration: 4570 nM
Beside the measured number, compound 3's estimate is 1.1-fold (0.06 log units) below it; the range from low to high includes it.
By their numbers in this assay, from the lowest: compound 1; then compounds 3 and 2 (each within the scatter of the next).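

Among these compounds, this is the first pair here that differs in only one place, so it gives a direct reading of the stereocentre at the saturated chain carbon: in this assay, turning it from S to R gives a 1.6-fold lower number from compound 2 to compound 3 (0.21 log units; within the scatter). A step of this size lies within the usual scatter of repeated measurements, so compound 2 and compound 3 cannot be told apart in this assay, and at this chain carbon the drawn configuration shows no measurable effect on inhibition. The comparison is a clean one, since no other structural change is mixed into the step: the fact that compounds 2 and 3 differ only in the configuration as drawn

Going by these compounds, the result covers one stereocentre in one setting, so the other stereocentre, drawn the same way in both compounds, remains untested by this pair. Also open, on these data alone, is whether the two configurations would still match if the chlorine on the shared core gave way to another group, such as a methoxy group, or if the amine side chain carried a longer chain.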